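Fluorine placement across two aryl rings in the series

A few compounds are considered here, and "the series" means these few. Any claim that something is new, unique, unknown or untested is made for them only; others in the source may bear on it.

Compound 1 `CCOc1cc(C)c(-c2cccc(CNc3ccc(OCC(=O)O)c(F)c3)c2)c(C)c1` and compound 2 `CCOc1cc(C)c(-c2cccc(CNc3ccc(OCC(=O)O)cc3)c2)c(C)c1` share a core; their difference is fluoro in place of hydrogen on an aromatic carbon. In a functional assay on CHO cells for agonist activity at Free fatty acid receptor 1 (Homo sapiens), read by FLIPR and calcium flux (on this read-out lower numbers stand for an effect already at smaller amounts and higher numbers for an effect only at larger amounts of compound), compound 1 gives 24.2 nM, while compound 2 gives 197 nM, a step of an 8.1-fold lower number from compound 2 to compound 1 (0.91 log units; beyond the scatter). Compound 3 `O=C(O)COc1ccc(NCc2cccc(-c3ccccc3)c2)cc1F` carries a smaller core; how its core differs from that of compound 2 is not broken down here. In this assay compound 3 gives 58.5 nM, which places it between compound 1 and compound 2.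

Compound 4 `O=C(O)COc1ccc(NCc2cccc(-c3ccccc3F)c2)cc1F` is not yet measured. Its difference from compound 3 is fluoro in place of hydrogen on an aromatic carbon. This is the same kind of change as that from compound 2 to compound 1, but not the same: in compound 1 the entering fluoro sits ortho to a carboxymethoxy group and meta to a large group, whereas in compound 4 it sits ortho to a large group, on the other ring of the biaryl. For the measured compounds named here, the earlier step, an 8.1-fold lower number from compound 2 to compound 1 (0.91 log units; beyond the scatter), therefore gives no direct guide to the present one, and no other measured pair shows a fluoro entering at this place.

With that in mind, the change from compound 3 to compound 4 is expected to be small, a 1.5-fold lower number from compound 3 to compound 4 (0.17 log units; within the scatter). For compound 4 a value of 40 nM is estimated in this assay, with a likely range from 15 nM to 120 nM.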

Compound 4, half-maximal effective concentration in the Free fatty acid receptor 1 assay: 36.5 nM
Beside the measured number, compound 4's estimate is 1.1-fold (0.04 log units) above it, within the range that was stated.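

In the Free fatty acid receptor 1 assay the fluoro entering ortho to a large group gives a 1.6-fold lower number from compound 3 to compound 4 (0.20 log units; within the scatter). In a physicochemical assay for lipophilicity, read by HPLC, in phosphate buffer, measured as octanol-water partition, at pH 7.4, tested at 100 uM (a higher number here means a more lipophilic compound, a lower number a more polar compound), compound 3 gives 2.25 and compound 4 gives 2.36. In the physicochemical assay the same change gives a number 0.11 log units higher from compound 3 to compound 4 (within the scatter). Fluoro in place of hydrogen on an aromatic carbon therefore does not carry over as a single step size in the Free fatty acid receptor 1 assay, and the two steps set side by side differ: the same change on two cores in the Free fatty acid receptor 1 assay, an 8.1-fold lower number (0.91 log units; beyond the scatter) from compound 2 to compound 1 and a 1.6-fold lower number (0.20 log units; within the scatter) from compound 3 to compound 4, 5.1-fold (0.71 log units) apart, beyond the scatter of two such steps This does not show whether the gap follows the core or the place of the fluoro, as the two steps differ in both and the fluoro of compound 1 and that of compound 4 stand on different rings, so two pairs give no rule for any further core.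

Still open, from the compounds shown here alone, is how hydrogen to fluoro reads on the core of compound 3 at the place the fluoro takes in compound 1, a comparison that would hold that place fixed and change only the core. Also open, going by these compounds, is whether a chloro or a methoxy group at the place taken by the fluoro in compound 4 would give a step of similar size in the Free fatty acid receptor 1 assay and in the physicochemical assay.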